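Moving one hydroxy group on a cytotoxic compound

A few compounds are considered here, and "the series" means these few. Any claim that something is new, unique, unknown or untested is made for them only; others in the source may bear on it.

compound 1 `COc1ccc(/C=C2\CCC/C(=C\c3cccc(Br)c3)C2=O)cc1OC`: 5200 nM
compound 2 `COc1ccccc1/C=C1\CCC/C(=C\c2ccc(OC)c(OC)c2)C1=O`: 8100 nM
compound 3 `COc1ccc(/C=C2\CCC/C(=C\c3cccc(O)c3)C2=O)cc1OC`: 1700 nM

In a functional assay on HT-1080 cells (Homo sapiens) for cytotoxicity, read by MTT assay, with a stated time of 72 h (a lower number here means a stronger inhibitor, a higher number a weaker inhibitor), compound 3 gives 1700 nM, the lowest of the three numbers. Its distance from the other two compounds is beyond the usual scatter: a 3.1-fold lower number from compound 1 to compound 3 (0.49 log units; beyond the scatter), and a 4.8-fold lower number from compound 2 to compound 3 (0.68 log units; beyond the scatter).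

The next compound to be tested is compound 4 `COc1ccc(/C=C2\CCC/C(=C\c3ccc(O)cc3)C2=O)cc1OC`. It has 4-hydroxyphenyl in place of 3-hydroxyphenyl on a double-bonded chain carbon bound to a double-bonded ring carbon. The same atoms are present, joined differently.

For the measured compounds named here, no measured step moves a hydroxy group, so the evidence is indirect. The three measured steps all change a group at this same place. The two that lead to compound 3 are modest, as shown above. The third, a 1.6-fold higher number from compound 1 to compound 2 (0.19 log units; within the scatter), stays within the scatter. None of these steps is large, and compound 4 keeps the hydroxy group of compound 3, so no step beyond the scatter is expected in this assay. A slightly higher number seems a little more likely than a lower one, though nothing measured settles the direction.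

The expected step is a 1.2-fold higher number from compound 3 to compound 4 (0.07 log units; within the scatter). For compound 4 the estimated value is 2000 nM, with an expected range of 700 nM to 6000 nM.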

Compound 4, half-maximal inhibitory concentration: 16800 nM
Compound 4: the middle estimate sits 8.4-fold (0.92 log units) below what was measured, and the stated range ends below it.
By their numbers in this assay, from the lowest: compound 3; then compounds 1 and 2 (each within the scatter of the next); then compound 4.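

In this assay, this place on the shared core distinguishes between two groups that are built from the same atoms: 4-hydroxyphenyl in place of 3-hydroxyphenyl gives the largest step seen so far (a 9.9-fold higher number from compound 3 to compound 4 (0.99 log units; beyond the scatter)). A hydroxy group alone therefore does not bring a lower number, since compound 3 has the lowest number of the four, while compound 4 has the highest, even compared with the compounds that have no hydroxy group on this ring (a 2.1-fold higher number from compound 2 to compound 4 (0.32 log units; beyond the scatter); a 3.2-fold higher number from compound 1 to compound 4 (0.51 log units; beyond the scatter)). What matters here is where the hydroxy group stands on the ring as well as whether it is present, but nothing available explains why moving it has an effect of this size.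

Still open, as far as these compounds go, is whether a 3-aminophenyl or 4-aminophenyl group at this place would follow the pattern of the two hydroxyphenyl groups, and whether a carboxylic acid on the same ring would do so too. The compounds shown also leave open whether the gap between compound 3 and compound 4 would persist if the 3,4-dimethoxyphenyl group on the other side of the core were replaced.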